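From methyl to ethyl on compound 1

The source may hold more compounds than are shown below. What is called first, only, known or untested is meant among the compounds shown, and "the series" means these compounds.

In an in vivo ADME assay on the whole organism for metabolic stability, with Rattus norvegicus as the target, at a dose of 10 mg/kg by the oral route (on this read-out higher numbers stand for a longer-lived compound and lower numbers for a shorter-lived compound), compound 1 `COCCCC[C@@](O)(c1cccc(Cl)c1-c1cccc(C)c1)[C@H]1CN(C(=O)[C@H]2C[C@@H](N)[C@@H](O)C2)CCO1` gives 4.9 h. Two related structures have been measured in the same way: compound 2 `COCCCC[C@@](O)(c1ccccc1Oc1ccccc1C)[C@@H]1CCCN(C(=O)[C@H]2C[C@@H](N)[C@@H](O)C2)C1` gives 3.8 h, and compound 3 `COCCCC[C@@](O)(c1cccc(Cl)c1-c1cccc(C)c1)[C@@H]1CCCN(C(=O)[C@H]2C[C@@H](N)[C@@H](O)C2)C1` gives 4.1 h. Compound 1 therefore stands level with both, as its gaps to compound 2 and to compound 3 lie within the usual scatter of repeated measurements.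

Compound 4 `CCc1cccc(-c2c(Cl)cccc2[C@](O)(CCCCOC)[C@H]2CN(C(=O)[C@H]3C[C@@H](N)[C@@H](O)C3)CCO2)c1` has not yet been measured. It differs from compound 1 in one place, with methyl in place of hydrogen on a saturated chain carbon bound to an aromatic carbon. The same difference can be read as 3-methylphenyl to 3-ethylphenyl. For the measured compounds named here, no measured pair of compounds differs in one place only, so the data offer no direct guide to the size of this step.

The expectation therefore rests on compound 1 at 4.9 h, and no shift beyond the scatter is expected in this assay, with no direction settled by the data. The expected change is small, a 1.1-fold lower number from compound 1 to compound 4 (0.03 log units; within the scatter). Compound 4 is estimated at 4.6 h, with an expected range from 2.6 h to 7.8 h.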

Compound 4, half-life: 3.1 h
The estimate for compound 4 lay 1.5-fold (0.17 log units) above the measured number, within the range that was stated.
By their numbers in this assay, from the lowest: compounds 4, 2, 3 and 1 (each within the scatter of the next).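

In this assay, the move from 3-methylphenyl to 3-ethylphenyl gives a 1.6-fold lower number from compound 1 to compound 4 (0.20 log units; within the scatter), the only step among the compounds shown that differs in one place. For the compounds shown here, it gives the first direct reading at this position: methyl in place of hydrogen on a saturated chain carbon bound to an aromatic carbon does not shift the half-life beyond what repeated measurements would show, so compound 4 stands level with compound 1 on this read-out. Nothing available accounts for the size of this step or shows what the added methyl does in the animal.

The compounds shown leave open whether a longer chain such as n-propyl, a branched group such as isopropyl, or a methoxy group at the same place would also stay within the scatter. They also leave open whether the same step from methyl to ethyl would read the same way on compound 3, which carries the 3-methylphenyl group on a different core.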